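The compounds below may be only part of what the source reports. "The series", "measured", "known", "first", "only" and "open" are said of these compounds alone.

In a functional assay on K562 cells (Homo sapiens) for inhibition, read by MTT assay, with a stated time of 48 h (a higher number here means a weaker inhibitor, a lower number a stronger inhibitor), compound 1 `O=C(Nc1nc2ccc(-c3cn([C@@H]4CN[C@H](C(=O)Nc5ccc(Cl)cc5Cl)C4)nn3)nc2s1)C1CC1` gives 740 nM and compound 2 `CC(=O)Nc1nc2ccc(-c3cn([C@@H]4CN[C@H](C(=O)Nc5ccc(Br)cc5)C4)nn3)nc2s1` gives 5020 nM as the higher of the two numbers, beyond the scatter. Compound 3 `O=C(Nc1nc2ccc(-c3cn([C@@H]4CN[C@H](C(=O)Nc5ccc(Br)cc5)C4)nn3)nc2s1)C1CC1` differs from compound 2 by cyclopropyl in place of methyl on a carbonyl carbon with cyclopropyl in place of methyl on a carbonyl carbon. Within the data shown here, no measured step isolates this change. Compound 1 also carries cyclopropyl on a carbonyl carbon and gives 740 nM with other differences from compound 2, so a moderate fall in number is expected. The estimated change is a 2.5-fold lower number from compound 2 to compound 3 (0.40 log units; beyond the scatter) in the lower direction. The estimate for compound 3 is 2000 nM with an expected range from 750 nM to 5500 nM as working figures.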

Compound 3, half-maximal inhibitory concentration: 8160 nM
The estimate for compound 3 lay 4.1-fold (0.61 log units) below the measured number; measured number outside the range, above it.
By their numbers in this assay, from the lowest: compound 1; then compounds 2 and 3 (each within the scatter of the next).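

In this assay cyclopropyl in place of methyl on the carbonyl carbon gives a 1.6-fold higher number from compound 2 to compound 3 (0.21 log units; within the scatter) and so shows no separable change at this position with 4-bromophenyl on the amide-type nitrogen. 4-Bromophenyl in place of 2,4-dichlorophenyl on that nitrogen gives an 11-fold higher number from compound 1 to compound 3 (1.04 log units; beyond the scatter) as the large step, so the difference among these compounds tracks that aryl group and not the acyl group. No available data bear on the cause of either step.

Going by these compounds, whether the acyl change behaves the same way with 2,4-dichlorophenyl on the nitrogen remains open. Also open, on these data alone, is how a longer chain or an amine on the carbonyl carbon would read.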